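The compounds below may be only part of what the source reports. "The series", "measured", "known", "first", "only" and "open" are said of these compounds alone.

Among the measured compounds shown here, compound 2 `Cc1cc(C(=O)Nc2ccc3nc(NC(=O)C4CCCCC4)sc3c2)n(C)n1` holds the only plain number among the values shown: in a functional assay on WI-38 VA13 cells (Homo sapiens) for cytotoxicity (on this read-out lower numbers stand for an effect already at smaller amounts and higher numbers for an effect only at larger amounts of compound), compound 2 gives 0.12 ug/mL. Compound 1 `O=C(Nc1ccc2nc(NC(=O)C3CCCCC3)sc2c1)c1ccc(Br)cc1` gives only a limit in this assay, namely > 4 ug/mL. For the measured compounds named here, the single measured step, an at least 33-fold lower number from compound 1 to compound 2 (1.52 log units; beyond the scatter), is the sole guide, and it bears only loosely on the present change, since it exchanges a different group. Compound 3 `Cc1cc(C(=O)Nc2ccc3nc(NC(=O)C4CCCCC4)sc3c2)c(C)n1C` differs from compound 2 by 1,2,5-trimethyl-1H-pyrrol-3-yl in place of 1,3-dimethyl-1H-pyrazol-5-yl on a carbonyl carbon. Going by the values given here, with no closer step to go by, the step of a 1.7-fold higher number from compound 2 to compound 3 (0.22 log units; within the scatter) is expected to stay within the scatter. Compound 3 is therefore estimated at 0.2 ug/mL, with a range from 0.05 ug/mL to 1 ug/mL.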

Compound 3, half-maximal effective concentration: > 6.2 ug/mL
Compound 3 gave a limit, no number; the forecaster's own chance of this, stated with the estimate: 15%; middle value at least 31-fold (1.49 log units) away from the limit.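

On a carbonyl carbon whose other neighbour is an amide-type nitrogen, 1,2,5-trimethyl-1H-pyrrol-3-yl in place of 1,3-dimethyl-1H-pyrazol-5-yl gives an at least 51-fold higher number from compound 2 to compound 3 (1.71 log units; beyond the scatter), so the low number of compound 2 does not extend to every five-membered aromatic ring at this place. Compound 1 and compound 3 both give limits, and the step between them cannot be read. Compound 3 stands at a limit of the assay: the limit of > 6.2 ug/mL in this assay, at which 1 of the 3 values shown sits.

The compounds shown do not separate the change in ring hetero atoms from the change in methyl groups. On these data alone, how a pyridin-3-yl group at this place would read also stays open.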